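The source may report more compounds than this note shows. Statements on the series, on what has been measured and on what is new or still open speak of the compounds shown alone.

Compound 1 `CCCCCCCCCCCC[C@@H](O)[C@H]1CC[C@H]([C@H](O)CCCCCCCCCCNC(=O)c2ccoc2)O1`: 100000 nM
Compound 2 `CCCCCCCCCCCC[C@@H](O)[C@H]1CC[C@H]([C@H](O)CCCCCCCCCCNC(=O)c2cncs2)O1`: 100000 nM

In a functional assay on HBC4 cells (Homo sapiens) for inhibition, read by colorimetric assay and sulforhodamine B assay, with a stated time of 48 h (a higher number here means a weaker inhibitor of growth, a lower number a stronger inhibitor of growth), compound 2 gives 100000 nM, level with compound 1. Compound 3 `CCCCCCCCCCCC[C@@H](O)[C@H]1CC[C@H]([C@H](O)CCCCCCCCCCNC(=O)c2ccnn2C)O1` carries 1-methyl-1H-pyrazol-5-yl in place of 1,3-thiazol-5-yl on a carbonyl carbon. For the measured compounds named here, one measured step bears on this, a swap on the same carbonyl carbon, of furan-3-yl for 1,3-thiazol-5-yl: no change at the digits printed from compound 1 to compound 2 (within the scatter). With that single step as the guide, no step beyond the scatter is expected in this assay. The expected step is no change at the digits printed from compound 2 to compound 3 (within the scatter). The estimated value for compound 3 is 100000 nM, with an expected range from 30000 nM to 100000 nM.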

Compound 3, concentration for 50% growth inhibition: 100000 nM
Compound 3: the middle estimate sits on the measured number at the digits printed, and the stated range covers the measured number.
By their numbers in this assay, from the lowest: compounds 1, 2 and 3 (each within the scatter of the next).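

In this assay the change to 1-methyl-1H-pyrazol-5-yl on the carbonyl carbon shows no change at the digits printed from compound 2 to compound 3 (within the scatter), and set against furan-3-yl it shows no change at the digits printed from compound 1 to compound 3 (within the scatter). This adds a third group to the two already level at this position, and it is one with a methyl group on its ring and one heavy atom more than 1,3-thiazol-5-yl. Nothing available gives a reason for this result. The compounds leave open whether any group on this carbonyl carbon can move the value. A phenyl ring, an amine or a carboxylic acid there might do so, and a shorter chain might too.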